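Lengthening an Ether Chain: From Methoxy to Propoxy

The source may hold more compounds than are shown below. What is called first, only, known or untested is meant among the compounds shown, and "the series" means these compounds.

Of the compounds shown here, three built on one shared core have been tested in a functional assay on PC-3 cells (Homo sapiens) for inhibition, read by sulforhodamine B assay, with a stated time of 48 h, tested at 50 uM; a lower number here means less inhibition of growth, a higher number more inhibition of growth at the concentration tested. Compound 1 `COc1cc2c(cc1CC=C(C)C)C(=O)C[C@@H](c1ccc(Oc3ccccc3)cc1)O2` gives 53%. Compound 2 `COc1ccc([C@@H]2CC(=O)c3cc(CC=C(C)C)c(OC)cc3O2)cc1` carries methyl in place of phenyl on an oxygen on an aromatic ring and gives 58%; the step of a number 5 percentage points higher from compound 1 to compound 2 (within the scatter). Compound 3 `COc1cc2c(cc1CC1OC1(C)C)C(=O)C[C@@H](c1ccc(O)cc1)O2` differs from compound 2 in more than one place. Compound 3 gives 92%. Among these three numbers compound 2 stands second highest: compound 1 is its nearest neighbour, lower but within the scatter, while compound 3 sits higher, beyond the scatter.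

Compound 4 `CCCOc1ccc([C@@H]2CC(=O)c3cc(CC=C(C)C)c(OC)cc3O2)cc1` has not yet been measured. It differs from compound 2 by ethyl in place of hydrogen on a saturated chain carbon bound to an oxygen on an aromatic ring. Going by the values given here, the only measured step at the oxygen on the aromatic ring, from compound 1 to compound 2, exchanged one group on that oxygen for another and stayed within the scatter. Nothing measured shows what a longer chain does there. The estimated step is therefore no change at the digits printed from compound 2 to compound 4 (within the scatter), meaning no change beyond the scatter is expected. Compound 4 is estimated at 58%, with an expected range from 42% to 74%.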

Compound 4, percent growth inhibition at one concentration: 54%
Beside the measured number, compound 4's estimate is 4 percentage points above it; low and high end bracket the measured number.
By their numbers in this assay, from the lowest: compounds 1, 4 and 2 (each within the scatter of the next); then compound 3.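

Replacing methoxy with propoxy gives a number 4 percentage points lower from compound 2 to compound 4 (within the scatter) in this assay, and replacing the phenyl on the same oxygen with propyl gives a number 1 percentage points higher from compound 1 to compound 4 (within the scatter) as the second reading. The earlier compounds shown here covered only phenyl and methyl on this oxygen on an aromatic ring; with propyl as a third group, a saturated chain of this length also gives a number that cannot be told apart from the other two. No measurement at hand offers an explanation for this flat result.

Still open, going by these compounds, is whether the same holds for a longer chain, such as hexyl, on this oxygen. A chain ending in an amine or a carboxylic acid is also untested among the compounds shown, so the limits of this flat reading remain unknown.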